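The source may report more compounds than this note shows. Statements on the series, on what has been measured and on what is new or still open speak of the compounds shown alone.

Measured so far in an assay on isolated protein for inhibition of retinal dehydrogenase 2 (Homo sapiens); on this read-out higher numbers stand for weaker inhibition and lower numbers for stronger inhibition:
compound 1, `Cn1ncc2c(=O)n(-c3ccccc3)c(COc3cccc(F)c3)nc21`, gives 1770 nM
compound 2, `Cn1ncc2c(=O)n(-c3ccccc3)c(SC(C)(C)c3ccccc3)nc21`, gives 2200 nM

Compound 2 and compound 1 sit within the scatter of each other in this assay; the two numbers show no separation. Compound 3, `CC(Sc1nc2c(cnn2C)c(=O)n1-c1ccccc1)c1ccccn1`, carries 1-(pyridin-2-yl)ethyl in place of 1-methyl-1-phenylethyl on a sulfur. Among the measured compounds shown here, no step between measured compounds bears on this change, so the numbers give no direction for it; the step that the estimate means is expected to be a 1.1-fold lower number from compound 2 to compound 3 (0.04 log units; within the scatter), nothing beyond the scatter. Compound 3 is accordingly estimated at 2000 nM, in the range 600 nM to 6500 nM.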

Compound 3, half-maximal inhibitory concentration: 63 nM
Compound 3: the middle estimate sits 32-fold (1.50 log units) above what was measured; measured number below the stated range.
By their numbers in this assay, from the lowest: compound 3; then compounds 1 and 2 (each within the scatter of the next).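

In this assay the group on the sulfur can move the read-out far beyond the scatter: 1-(pyridin-2-yl)ethyl in place of 1-methyl-1-phenylethyl gives a 35-fold lower number from compound 2 to compound 3 (1.54 log units; beyond the scatter) in a single change. The entering group has a hetero atom in its aromatic ring and a hydrogen-bond acceptor, while the leaving group has neither, and its carbon chain differs as well, so the step cannot be assigned to any one of these differences. No measurement at hand accounts for the step. Still open, on these data alone, is whether the ring nitrogen or the change in the chain carries the step; a 1-phenylethyl group on the sulfur would separate the two.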